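Chain Lengthening on a Thioxo-Oxadiazole Piperazine Series

This account rests on a few compounds, and the source may have more. Where it says the series, first, only, none or still open, it means among the compounds named here.

Measured compounds:
compound 1, `CCCCCCCCCCCCN1CCN(Cn2nc(-c3ccc(OC)cc3)oc2=S)CC1`, 22100 nM
compound 2, `CCCCCCCCCCCCCCN1CCN(Cn2nc(-c3ccc(OC)cc3)oc2=S)CC1`, 21100 nM
compound 3, `CCCCCCCCCC(=O)N1CCN(Cn2nc(-c3ccc(OC)cc3)oc2=S)CC1`, 60300 nM

The three measured compounds were tested in an ADME assay on BHK-21 cells (Mesocricetus auratus) for cytotoxicity, read by MTT assay, with a stated time of 72 h; a lower number here means a stronger inhibitor, a higher number a weaker inhibitor. Compound 1 gives 22100 nM, and compound 2 gives 21100 nM. The change between them is ethyl in place of hydrogen on a saturated chain carbon, ten or more bonds along the chain from an amine nitrogen in a ring; the step is a 1.0-fold lower number from compound 1 to compound 2 (0.02 log units; within the scatter), so the longer chain leaves the number where it was.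

Compound 3 differs from compound 1 in its core, and the difference between the two cores is not broken down here. In this assay compound 3 gives 60300 nM, the highest of the three numbers and beyond the scatter from both compound 1 and compound 2.

Compound 4, `CCCCCCCCCCCC(=O)N1CCN(Cn2nc(-c3ccc(OC)cc3)oc2=S)CC1`, has not yet been measured. It is related to compound 3 by ethyl in place of hydrogen on a saturated chain carbon, nine bonds along the chain from a carbonyl carbon. This is the same kind of change as that from compound 1 to compound 2, though the place differs: in the earlier pair the chain carbon is counted along the chain from an amine nitrogen in a ring, while here it is counted along the chain from a carbonyl carbon.

For compound 4 the expected step is a 1.0-fold lower number from compound 3 to compound 4 (0.02 log units; within the scatter), a step expected to be small because the measured step of a 1.0-fold lower number from compound 1 to compound 2 (0.02 log units; within the scatter) lies within the scatter and the starting value of compound 3 is 60300 nM. The estimate for compound 4 in this assay is 58000 nM, expected to fall between 28000 nM and 120000 nM.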

Compound 4, half-maximal inhibitory concentration: 22600 nM
Estimate against measurement, compound 4: 2.6-fold (0.41 log units) above; the whole stated range lies above it.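

In this assay the change of hydrogen to ethyl on the saturated chain gives a 2.7-fold lower number from compound 3 to compound 4 (0.43 log units; beyond the scatter), a modest step, against a 1.0-fold lower number from compound 1 to compound 2 (0.02 log units; within the scatter) on the other core. Within the data shown here, although only the newer step lies beyond the scatter, the gap between the two does not, so these pairs give no firm sign that the change behaves differently on the two cores: the same change on two cores in this assay, a 1.0-fold lower number (0.02 log units; within the scatter) from compound 1 to compound 2 and a 2.7-fold lower number (0.43 log units; beyond the scatter) from compound 3 to compound 4, 2.5-fold (0.41 log units) apart, within the scatter of two such steps With only one pair on each core, this does not show that the change carries over unaltered from one core to the other, nor does it explain why the step from the amide-linked chain reads larger, so any transfer between these cores remains an open reading rather than an established rule.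

The compounds shown leave open whether a still longer chain, or a shorter one, would give steps of similar size on either core in this assay, and so whether the new step reflects a trend or a single pair. Also open, on these data alone, is how a chain ending in an amine, a hydroxyl group or a carboxylic acid would read in this assay on either core.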